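Simplifying the imide of compound 3: a small expected shift

The source may report more compounds than this note shows. Statements on the series, on what has been measured and on what is new or still open speak of the compounds shown alone.

Compound 1, `Cc1cc(Cl)cc(-c2ccnc3cc(CN4C(=O)CCC4=O)sc23)c1O[C@H]1C[C@H](N)C1`, gives 150 nM in an assay on RKO cells for inhibition of ubiquitin carboxyl-terminal hydrolase 7 (Homo sapiens), read by a luciferase reporter, with a stated time of 18 h; a higher number here means that more compound is needed for the effect, a lower number that less compound is needed.
Compound 2, `Cc1cc(Cl)cc(-c2ccnc3cc(CN4C(=O)CCC4=O)sc23)c1CN1[C@@H](C)CNC[C@@H]1C`, gives 60 nM in this assay.
Compound 3, `Cc1cc(Cl)cc(-c2ccnc3cc(CN4C(=O)C5CC5C4=O)sc23)c1O[C@@H]1CCNC[C@@H]1C`, gives 170 nM in this assay.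

In this assay compound 3 has the highest number of the three, but its gap to compound 1 lies within the scatter, so the two cannot be ordered; only compound 2 is clearly lower. Among the compounds with values here, the single measured one-place step, a 2.5-fold lower number from compound 1 to compound 2 (0.40 log units; beyond the scatter), concerns the substituent on the aromatic carbon, not the imide, and so does not bear on the change examined here.

Compound 4 is `Cc1cc(Cl)cc(-c2ccnc3cc(CN4C(=O)CCC4=O)sc23)c1O[C@@H]1CCNC[C@@H]1C`. Compared with compound 3 the change is a group of 7 heavy atoms (4 carbon, 1 nitrogen, 2 oxygen; one five-membered non-aromatic ring with 1 hetero atom) in place of a group of 8 heavy atoms (5 carbon, 1 nitrogen, 2 oxygen; one three-membered non-aromatic ring of carbon only, one five-membered non-aromatic ring with 1 hetero atom), on a saturated chain carbon bound to an aromatic carbon. Within the data shown here, no measured step isolates this change. Compounds 1 and 2 carry the same imide that enters in compound 4, yet each also differs from compound 3 in the group on the aromatic carbon, so their values only show that both imides sit alongside numbers of similar size.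

Compound 4 is therefore expected to give a number close to that of compound 3, with a 1.3-fold lower number from compound 3 to compound 4 (0.12 log units; within the scatter) as the estimated step, not beyond the scatter. The estimate for compound 4 in this assay is 130 nM, with a range of 60 nM to 300 nM.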

Compound 4, half-maximal effective concentration: 150 nM
Compound 4: the middle estimate sits 1.2-fold (0.06 log units) below what was measured, and the stated range covers the measured number.
By their numbers in this assay, from the lowest: compound 2; then compounds 1, 4 and 3 (each within the scatter of the next).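

In this assay, the change of imide on a saturated chain carbon bound to an aromatic carbon can now be read on its own: a 1.1-fold lower number from compound 3 to compound 4 (0.05 log units; within the scatter), so the 2,5-dioxopyrrolidin-1-yl group and the imide with the three-membered carbon ring cannot be ordered here. With the 2,5-dioxopyrrolidin-1-yl group held constant, the group on the oxygen on an aromatic ring can also be read, and 3-methylpiperidin-4-yl in place of 3-aminocyclobutyl gives no change at the digits printed from compound 1 to compound 4 (within the scatter), so these two groups cannot be ordered either. The group on the aromatic carbon does separate compounds: (3-methylpiperidin-4-yl)oxy in place of (2,6-dimethylpiperazin-1-yl)methyl gives a 2.5-fold higher number from compound 2 to compound 4 (0.40 log units; beyond the scatter), which leaves compound 2 apart from compound 4 as it is from compound 1.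

Nothing at hand accounts for the size of any of these steps. Still open, as far as these compounds go, is whether a different group on that saturated chain carbon, such as an open-chain amide or a carboxylic acid, would shift the number, and whether the imide with the three-membered carbon ring would give a similar number alongside the (2,6-dimethylpiperazin-1-yl)methyl group.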